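This account rests on a few compounds, and the source may have more. Where it says the series, first, only, none or still open, it means among the compounds named here.

Measured compounds:
compound 1 `CC(=O)N1N=C(c2ccc(Br)cc2)CC1c1cccc(Cl)c1Cl` gives 38800 nM in a functional assay on PC-3 cells (Homo sapiens) for cytotoxicity, read by sulforhodamine B assay, with a stated time of 48 h; on this read-out higher numbers stand for weaker inhibition and lower numbers for stronger inhibition
compound 2 `CC(=O)N1N=C(c2ccco2)CC1c1ccc(Br)cc1` gives 42100 nM
compound 3 `CC(=O)N1N=C(c2cccc3ccccc23)CC1c1ccccc1` gives 8460 nM

Among these three, compound 3 stands at the lowest number in this assay. Its nearest neighbour is compound 1, whose number lies beyond the scatter above it, and compound 2 lies further still, also beyond the scatter. Among the measured compounds shown here, no two of the measured compounds differ in one place only, so no single step between them can be read from these numbers.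

Compound 4 `CC(=O)N1N=C(c2cccc3ccccc23)CC1/C=C/c1ccccc1` differs from compound 3 by one change: 2-phenylethenyl in place of phenyl on a saturated ring carbon. For the measured compounds named here, nothing among the measured compounds shows what this exchange does, so the expectation rests on the change itself. A step of modest size is expected for the move from compound 3 to compound 4, a 1.3-fold lower number from compound 3 to compound 4 (0.11 log units; within the scatter), most likely staying within the scatter of this assay in either direction. Compound 4 is therefore estimated at 6500 nM, with a range from 2200 nM to 19000 nM.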

Compound 4, half-maximal inhibitory concentration: 21100 nM
For compound 4 the middle estimate is 3.2-fold (0.51 log units) below the measured one; the measured number lies above the stated range.
By their numbers in this assay, from the lowest: compound 3; then compounds 4, 1 and 2 (each within the scatter of the next).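

In this assay this first single-place step shows that the substituent on the saturated ring carbon does affect the read-out: 2-phenylethenyl in place of phenyl gives a 2.5-fold higher number from compound 3 to compound 4 (0.40 log units; beyond the scatter). The aromatic ring is kept in this exchange, yet the added carbons and the double bond outside the aromatic ring come with weaker inhibition, so phenyl cannot be extended in this way without a loss at this position. Nothing available accounts for this step.

From the compounds shown here alone, how a saturated 2-phenylethyl chain, a benzyl group or an amine on this carbon would compare remains open, so the part played by the double bond cannot be separated from that of the added carbons. Going by these compounds, whether the same step would hold on the cores of compound 1 and compound 2 is also open.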